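Replacing the (carbamoylcarbonyl)methyl group of compound 3

The source may report more compounds than this note shows. Statements on the series, on what has been measured and on what is new or still open speak of the compounds shown alone.

Measured in a functional assay on HEL cells (Homo sapiens); a higher number here means that more compound is tolerated, a lower number that less compound is tolerated:
- compound 1 `CC(=O)NC1=CS(=O)(=O)O[C@@]12[C@@H](CO[Si](C)(C)C(C)(C)C)O[C@@H](n1cc(C)c(=O)n(C)c1=O)[C@@H]2O[Si](C)(C)C(C)(C)C`: > 200000 nM (a limit)
- compound 2 `Cc1cn([C@@H]2O[C@H](CO[Si](C)(C)C(C)(C)C)[C@@]3(OS(=O)(=O)C=C3NCC(=O)C(=O)O)[C@H]2O[Si](C)(C)C(C)(C)C)c(=O)n(C)c1=O`: 146000 nM
- compound 3 `Cc1cn([C@@H]2O[C@H](CO[Si](C)(C)C(C)(C)C)[C@@]3(OS(=O)(=O)C=C3NCC(=O)C(N)=O)[C@H]2O[Si](C)(C)C(C)(C)C)c(=O)n(C)c1=O`: 14500 nM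

Compound 3 gives the lower of the two actual numbers, 14500 nM, and its nearest neighbour is compound 2 with 146000 nM. For compound 1 the assay reports only a limit, > 200000 nM.

Compound 4 `CCNC(=O)NC1=CS(=O)(=O)O[C@@]12[C@@H](CO[Si](C)(C)C(C)(C)C)O[C@@H](n1cc(C)c(=O)n(C)c1=O)[C@@H]2O[Si](C)(C)C(C)(C)C` has yet to be measured in this assay. It carries ethylcarbamoyl in place of (carbamoylcarbonyl)methyl on an amine nitrogen.

All three measured steps bear on this change, since each alters the same side chain. The largest is an at least 13-fold lower number from compound 1 to compound 3 (1.13 log units; beyond the scatter). The step of a 10-fold lower number from compound 2 to compound 3 (1.00 log units; beyond the scatter) is modest, showing that the end of the chain matters on its own. The step of an at least 1.3-fold lower number from compound 1 to compound 2 (0.13 log units; that floor lies within the scatter) has a floor within the scatter. Ethylcarbamoyl, like the acetyl of compound 1, joins the nitrogen through a carbonyl, so compound 4 is expected to undo much of an at least 13-fold lower number from compound 1 to compound 3 (1.13 log units; beyond the scatter).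

The expected change is a 5.5-fold higher number from compound 3 to compound 4 (0.74 log units; beyond the scatter), a move to a higher number beyond the scatter. Compound 4 is estimated at 80000 nM, with an expected range from 20000 nM to 200000 nM.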

Compound 4, half-maximal cytotoxic concentration: 10000 nM
For compound 4 the middle estimate is 8.0-fold (0.90 log units) above the measured one; the whole stated range lies above it.
By their numbers in this assay, from the lowest: compounds 4 and 3 (each within the scatter of the next); then compound 2. At a limit, above all of these: compound 1.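

In this assay, ethylcarbamoyl and (carbamoylcarbonyl)methyl on this amine nitrogen cannot be told apart, a 1.5-fold lower number from compound 3 to compound 4 (0.16 log units; within the scatter), so a carbonyl joined directly to that nitrogen does not by itself bring the number back towards that of the acetyl compound. The change is large against the chain ending in the acid, a 15-fold lower number from compound 2 to compound 4 (1.16 log units; beyond the scatter), and the change from acetyl is also large, an at least 20-fold lower number from compound 1 to compound 4 (1.30 log units; beyond the scatter), which shows that ethylamino in place of methyl on that carbonyl carbon is enough on its own to separate the two compounds. Compound 1 is known only as a limit, > 200000 nM, and the step from it is therefore a floor: the limit of > 200000 nM in this assay, at which 1 of the 4 values shown sits.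

The compounds shown leave open how much of this depends on the ethylamino part, as an unsubstituted amino group, a methylamino group or a longer chain such as butylamino on the same carbonyl carbon would show. They also leave open whether the close numbers of compound 3 and compound 4 would hold with hydroxy groups in place of the silyl ethers on the shared core.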